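Swapping Chloro for Bromo on a Sulfonamide Thiourea Aniline

The compounds below may be only part of what the source reports. "The series", "measured", "known", "first", "only" and "open" are said of these compounds alone.

Compound 1, `COc1cc2ncnc(Nc3ccc(OCc4cccc(F)c4)c(Cl)c3)c2cc1OCCCCC(=O)Nc1ccc(S(N)(=O)=O)cc1`, gives 7790 nM in a functional assay on A-431 cells (Homo sapiens) for antiproliferative activity, read by MTT assay, with a stated time of 72 h; on this read-out lower numbers stand for stronger inhibition and higher numbers for weaker inhibition.
Compound 2, `NS(=O)(=O)c1ccc(NC(=S)Nc2ccc3ncnc(Nc4ccc(F)c(Cl)c4)c3c2)cc1`, gives 37600 nM in this assay.

For the measured compounds named here, of the two compounds measured so far, compound 2 stands at the higher number, meaning weaker inhibition, and compound 1 stands at a lower number, a gap beyond the usual scatter of repeated measurements. Going by the values given here, the two compounds differ in many places at once, so no single structural step between them can be read from their values.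

Compound 3, `NS(=O)(=O)c1ccc(NC(=S)Nc2ccc3ncnc(Nc4ccc(F)c(Br)c4)c3c2)cc1`, has not yet been measured. It differs from compound 2 in one place only: bromo in place of chloro on an aromatic carbon. The change exchanges one halogen for another and touches nothing else in the molecule. Among the compounds with values here, with no measured pair of this kind to lean on, the expectation rests on the smallness of the change, and I expect a step in this assay that lies within the scatter, in no particular direction, as expressed by a 1.2-fold lower number from compound 2 to compound 3 (0.07 log units; within the scatter). For compound 3 the estimated value is 32000 nM, with a range from 12000 nM to 85000 nM.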

Compound 3, half-maximal inhibitory concentration: 18200 nM
Compound 3: the middle estimate sits 1.8-fold (0.25 log units) above what was measured; measured number inside the range.
By their numbers in this assay, from the lowest: compound 1; then compound 3; then compound 2.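

Going from the 3-chloro-4-fluorophenyl group to the 3-bromo-4-fluorophenyl group gives a 2.1-fold lower number from compound 2 to compound 3 (0.32 log units; beyond the scatter) in this assay. For the compounds shown here, this shows that the halogen ortho to a fluoro group is not a silent position: exchanging one heavy atom for another, with the counts of hydrogen-bond donors and acceptors unchanged, is enough to carry a modest step just past the usual scatter, and it is the first step here that can be tied to a single place in the molecule. Nothing available explains why bromo gives the lower number at this position.

Among the compounds shown, only chloro and bromo occupy this position, so it remains open how a methyl group, a trifluoromethyl group or a nitrile would behave there. Also open, from the compounds shown here alone, is whether the same exchange of chloro for bromo would give a similar step in compound 1, which also carries a chloro group but differs from compound 2 in many other places.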